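Benzyloxy acetophenone series: bromo replacing methyl

The compounds below may be only part of what the source reports. "The series", "measured", "known", "first", "only" and "open" are said of these compounds alone.

Compound 1 `CC(=O)c1ccc(OCc2cccc(C)c2)cc1` is measured in an assay on isolated protein for inhibition of Amine oxidase [flavin-containing] B (Homo sapiens), read by Amplex Red, with a stated time of 15 min (on this read-out lower numbers stand for stronger inhibition and higher numbers for weaker inhibition), where compound 1 gives 86.3 nM. Compound 2 `CC(=O)c1ccc(OCc2ccccc2C(F)(F)F)cc1` in this assay gives 183 nM, so compound 1 holds the lowest of the two numbers in hand, and the gap between the two lies beyond the scatter. Going by the values given here, no step between measured compounds that differ in a single place has been taken so far, so the next step has no measured precedent.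

Compound 3 `CC(=O)c1ccc(OCc2cccc(Br)c2)cc1` is the next compound to be measured in this assay. It differs from compound 1 as follows: bromo in place of methyl on an aromatic carbon, meta to a large group. Among the compounds with values here, with no comparable step measured, the expectation is a step of a 1.2-fold lower number from compound 1 to compound 3 (0.06 log units; within the scatter), not beyond the scatter in either direction. Compound 3 is accordingly estimated at 75 nM, within a range from 30 nM to 180 nM.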

Compound 3, half-maximal inhibitory concentration: 214 nM
Compound 3: middle estimate off by 2.9-fold (0.46 log units), on the low side; the whole stated range lies below it.
By their numbers in this assay, from the lowest: compound 1; then compounds 2 and 3 (each within the scatter of the next).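

Going by these compounds alone, this is the first single-place step: on the aromatic carbon meta to a large group, bromo in place of methyl gives a 2.5-fold higher number from compound 1 to compound 3 (0.39 log units; beyond the scatter) in this assay. The exchange swaps one heavy atom for one heavy atom and leaves the counts of hydrogen-bond donors, hydrogen-bond acceptors and net charge unchanged, yet the position still distinguishes the two groups, with methyl giving the lower number. Nothing measured in hand accounts for this difference.

The compounds shown leave open how chloro, methoxy or an amine would read at this same place. They also leave open whether bromo in place of methyl gives a step of similar size on other aromatic carbons, since this single step sets no trend.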